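The compounds below may be only part of what the source reports. "The series", "measured", "known", "first", "only" and "open" are said of these compounds alone.

In a functional assay on CWR22R cells (Homo sapiens) for antiproliferative activity, with a stated time of 96 h (on this read-out lower numbers stand for stronger inhibition and higher numbers for weaker inhibition), compound 1 (`Cc1cc(=O)oc2cc(OCC(=O)c3ccc(F)cc3)ccc12`) gives > 100000 nM, which is a limit and not a number. Compound 2 (`Cc1cc(=O)oc2cc(OCC(=O)c3ccc(C#N)cc3)ccc12`) gives > 100000 nM, also a limit. Compound 3 (`Cc1cc(=O)oc2cc(OCC(=O)c3ccc(OC(F)(F)F)cc3)ccc12`) gives > 100000 nM, again a limit. The three therefore share one position: the limit of > 100000 nM in this assay, at which 3 of the 3 values shown sit. Compound 4 (`O=C(COc1ccc2c(C(F)(F)F)cc(=O)oc2c1)c1ccc(F)cc1`) keeps the fluoro group of compound 1 and carries trifluoromethyl in place of methyl on an aromatic carbon. The nearest measured changes, a step that the two limits leave unreadable from compound 1 to compound 2 and a step that the two limits leave unreadable from compound 1 to compound 3, replace fluoro rather than methyl, and neither has a readable size. Starting from compound 1 and its limit of > 100000 nM, no step beyond the scatter is expected in this assay, in either direction. The expected change is a number no higher from compound 1 to compound 4 (the limit leaves the size open). Compound 4 is estimated at 100000 nM, within a range of 30000 nM to 300000 nM.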

Compound 4, half-maximal inhibitory concentration: "not active" (no number reported)
The entry for compound 4 holds no number; no gap can be computed for the estimate.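

Going by these compounds alone, compound 4 is reported without a number and compound 1 holds only a limit, so no step between compound 1 and compound 4 can be read. The compounds shown leave open whether trifluoromethyl in place of methyl changes antiproliferative activity at all.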